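Pyrazolyl in place of phenyl on the benzyl arm

A few compounds are considered here, and "the series" means these few. Any claim that something is new, unique, unknown or untested is made for them only; others in the source may bear on it.

Measured compounds:
Compound 1 `COc1c(N2CC[C@@H](CN)C2)c(F)cc2c(=O)c(C(=O)O)cn(Cc3ccc(-n4cccn4)cc3)c12` in an assay on isolated protein for inhibition of DNA topoisomerase 1 (Homo sapiens), with a stated time of 15 min; on this read-out higher numbers stand for weaker inhibition and lower numbers for stronger inhibition: > 200000 nM, a limit of the assay.
Compound 2 `CNC[C@@H]1CCN(c2cc3c(cc2F)c(=O)c(C(=O)O)cn3Cc2ccc(-n3cccn3)cc2)C1` in this assay: > 200000 nM, again a limit.
Compound 3 `NC[C@@H]1CCN(c2cc3c(cc2F)c(=O)c(C(=O)O)cn3Cc2ccc(-c3ccccc3)cc2)C1` in this assay: 15600 nM.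

Among the compounds with values here, compound 3 is the only member of the set with a measured number; the other two values are limits, and the limit is described by the limit of > 200000 nM in this assay, at which 2 of the 3 values shown sit. Within the data shown here, compound 3 therefore stands alone, and no step between measured compounds can be drawn.

Compound 4 `NC[C@@H]1CCN(c2cc3c(cc2F)c(=O)c(C(=O)O)cn3Cc2ccc(-n3cccn3)cc2)C1` is not yet measured. It differs from compound 3 in one place: 1H-pyrazol-1-yl in place of phenyl on an aromatic carbon. Compounds 1 and 2 also carry the 1H-pyrazol-1-yl group, but each differs from compound 3 in further places as well, so their limits do not isolate this change.

Still, both bearers of the 1H-pyrazol-1-yl reached only the limit, while compound 3 gave a number. The expectation for compound 4 is a step toward weaker inhibition, beyond the usual scatter, of about a 4.5-fold higher number from compound 3 to compound 4 (0.65 log units; beyond the scatter). The estimated value for compound 4 in this assay is 70000 nM, with a range from 20000 nM to 200000 nM, and a real chance that only a limit is reported.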

Compound 4, half-maximal inhibitory concentration: 91600 nM
For compound 4 the middle estimate is 1.3-fold (0.12 log units) below the measured one; low and high end bracket the measured number.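

Phenyl to 1H-pyrazol-1-yl, para to a large group, now stands as an isolated change in this assay, with a 5.9-fold higher number from compound 3 to compound 4 (0.77 log units; beyond the scatter), and compound 4 keeps a measured number, so this group alone does not carry the value to the limit. With the 1H-pyrazol-1-yl group held, hydrogen in place of methyl on the amine nitrogen gives an at least 2.1-fold lower number from compound 2 to compound 4 (0.33 log units; beyond the scatter), and hydrogen in place of methoxy on an aromatic carbon gives an at least 2.1-fold lower number from compound 1 to compound 4 (0.33 log units; beyond the scatter). Both of these steps start from a limit of the assay and are therefore bounds rather than sizes: the limit of > 200000 nM in this assay, at which 2 of the 4 values shown sit.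

The compounds shown do not separate the smaller five-membered ring from its two nitrogens, which a pyridine or thiophene ring at this place could begin to address. Within the data shown here, also open is whether a methyl on the amine nitrogen or a methoxy on the core has the same direction of effect when phenyl is kept, as the comparison with compound 3 stops at the single change of group.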